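A few compounds are considered here, and "the series" means these few. Any claim that something is new, unique, unknown or untested is made for them only; others in the source may bear on it.

Working notes on the series, measured in a physicochemical assay for solubility, read by HPLC, in phosphate buffer, with a stated time of 24 h, at pH 7.4, tested at 100 uM; a higher number here means a more soluble compound, a lower number a less soluble compound. Compound 1 `O=C(CCCCCNc1c(NCc2ccccc2)c(=O)c1=O)NO` gives 75000000 nM and compound 2 `CC(C)(Nc1c(NCCCCCC(=O)NO)c(=O)c1=O)c1ccccc1` gives 88000000 nM. Compound 1 therefore stands level with compound 2, the two values lying within the scatter of each other. For the measured compounds named here, no two measured compounds differ in one place, so no measured step is available as a guide.

Compound 3 `Cc1ccc(Nc2c(NCCCCCC(=O)NO)c(=O)c2=O)cc1` is still unmeasured. It has the same atoms as compound 1, joined differently: 4-methylphenyl in place of benzyl on a nitrogen on an aromatic ring. The change is 4-methylphenyl in place of benzyl on a nitrogen on an aromatic ring.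

Compound 1 at 75000000 nM already sits close to the concentration tested, which leaves little room for a higher number. Going by the values given here, a lower number is thus the more likely direction in this assay, although no measured step supports it. The expected change is small and within the scatter, an estimated 1.7-fold lower number from compound 1 to compound 3 (0.22 log units; within the scatter). For compound 3 the estimated value is 45000000 nM, with an expected range of 15000000 nM to 90000000 nM.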

Compound 3, solubility: 8100000 nM
For compound 3 the middle estimate is 5.6-fold (0.74 log units) above the measured one; the measured number lies below the stated range.
By their numbers in this assay, from the lowest: compound 3; then compounds 1 and 2 (each within the scatter of the next).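

In this assay the place on a nitrogen on an aromatic ring gives its first readable step, a 9.3-fold lower number from compound 1 to compound 3 (0.97 log units; beyond the scatter) and so beyond the scatter, on going from benzyl to 4-methylphenyl. This change leaves the counts untouched, since both groups have the same heavy atoms, one six-membered aromatic ring of carbon only, and no hydrogen-bond donors or acceptors, so those counts alone do not track the number at this place. Nothing available bears on the reason for a step of this size.

The two compounds do not separate the part played by the methyl group from that of the change from benzylamino to an arylamino group, and plain phenyl at this place would be the direct link between them. From the compounds shown here alone, how far the step carries to other groups on the same nitrogen, such as 4-methoxyphenyl, a pyridyl ring or a benzyl bearing an amine, and whether it holds with a shorter or longer chain to the hydroxamic acid, stays open.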